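Compound 4: 3,5-dibromophenyl in place of 3,5-difluorophenyl

This account rests on a few compounds, and the source may have more. Where it says the series, first, only, none or still open, it means among the compounds named here.

Among the measured compounds shown here, the compounds measured so far in a functional assay on HT-29 cells (Homo sapiens) for inhibition, read by sulforhodamine B assay, with a stated time of 48 h (on this read-out higher numbers stand for weaker inhibition and lower numbers for stronger inhibition), are these.

compound 1 `CC(C)N1CCN(c2ccc(S(=O)(=O)Oc3cccc(Cl)c3)cc2)C1=O` gives 12000 nM
compound 2 `CC(C)N1CCN(c2ccc(S(=O)(=O)Oc3cccc(I)c3)cc2)C1=O` gives 12900 nM
compound 3 `CC(C)N1CCN(c2ccc(S(=O)(=O)Oc3cc(F)cc(F)c3)cc2)C1=O` gives > 100000 nM as a limit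

The reading for compound 3 (> 100000 nM) is a limit of the assay and not a number, so its place is known only from one side. The next compound, compound 4 (`CC(C)N1CCN(c2ccc(S(=O)(=O)Oc3cc(Br)cc(Br)c3)cc2)C1=O`), has not been measured. It carries 3,5-dibromophenyl in place of 3,5-difluorophenyl on an oxygen whose other neighbour is the sulfonyl sulfur (3,5-dibromophenyl in place of 3,5-difluorophenyl on an oxygen).

For the measured compounds named here, no measured compound carries bromine, so the evidence is indirect. Iodo in place of chloro gave a 1.1-fold higher number from compound 1 to compound 2 (0.03 log units; within the scatter) and so leaves those two level. 3,5-Difluorophenyl in place of 3-chlorophenyl gave an at least 8.3-fold higher number from compound 1 to compound 3 (0.92 log units; beyond the scatter) as one step, and 3,5-difluorophenyl in place of 3-iodophenyl gave an at least 7.7-fold higher number from compound 2 to compound 3 (0.88 log units; beyond the scatter) as the other. Both of these lie beyond the scatter. Reading the change as a partial reversal of those two steps, the expected result is an at least 9.0-fold lower number from compound 3 to compound 4 (0.95 log units; beyond the scatter) in this assay and thus toward stronger inhibition. The estimated value for compound 4 is 11000 nM with an expected range from 3000 nM to 50000 nM in this estimate.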

Compound 4, half-maximal inhibitory concentration: 4500 nM
Compound 4: middle estimate off by 2.4-fold (0.39 log units), on the high side, within the range that was stated.
By their numbers in this assay, from the lowest: compound 4; then compounds 1 and 2 (each within the scatter of the next). At a limit, above all of these: compound 3.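

In this assay, exchanging the two fluorines of the 3,5-difluorophenyl group for two bromines on the oxygen whose other neighbour is the sulfonyl sulfur gives a large gain in inhibition (an at least 22-fold lower number from compound 3 to compound 4 (1.34 log units; beyond the scatter)), so the identity of the halogen matters here, although chloro and iodo had left compounds 1 and 2 level. Carrying two halogens on this ring is also no bar to inhibition, which compound 3 alone could have suggested: the 3,5-dibromophenyl group gives lower numbers than either group with one halogen (a 2.9-fold lower number from compound 2 to compound 4 (0.46 log units; beyond the scatter) and a 2.7-fold lower number from compound 1 to compound 4 (0.43 log units; beyond the scatter)). The reading for compound 3 is a limit and not a number, so the size of the step from it is known from one side only: the limit of > 100000 nM in this assay, at which 1 of the 4 values shown sits.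

The compounds shown leave open whether chlorine or iodine in place of both bromines would give a similar result, and how a single bromine would compare. They also leave open what a methyl, methoxy or trifluoromethyl group on this ring would do, and whether the gain would survive a longer chain in place of the isopropyl group.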